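Methyl added to a sulfonyl hydrazide inhibitor

The source may report more compounds than this note shows. Statements on the series, on what has been measured and on what is new or still open speak of the compounds shown alone.

Measured so far:
compound 1, `Cc1cccc(NNS(=O)(=O)c2ccc(S(C)(=O)=O)cc2)c1`, in an assay for inhibition of Indoleamine 2,3-dioxygenase 1 (Homo sapiens), read by spectrophotometry, with stated times of 1 h and 4 h (on this read-out higher numbers stand for weaker inhibition and lower numbers for stronger inhibition), gives 43 nM.
compound 2, `CC(=O)Nc1ccc(S(=O)(=O)NNc2ccccc2)cc1`, in this assay gives 71 nM.

Going by the values given here, compound 2 stands at the higher of the two numbers, and its only neighbour is compound 1, whose number differs from it by an amount that lies within the scatter of repeated measurements. The two compounds are therefore not separable on these results, and compound 2 cannot be called weaker.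

Compound 3, `CC(=O)Nc1ccc(S(=O)(=O)NNc2ccc(C)cc2)cc1`, differs from compound 2 in one place: methyl in place of hydrogen on an aromatic carbon. Among the compounds with values here, no pair of measured compounds isolates this change, so no measured step can be borrowed. With the two known values so close together, the expectation for the step from compound 2 to compound 3 is small and not beyond the scatter, estimated as a 1.3-fold lower number from compound 2 to compound 3 (0.11 log units; within the scatter). Compound 3 is expected to give 55 nM, within a range from 20 nM to 160 nM.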

Compound 3, half-maximal inhibitory concentration: 51 nM
For compound 3 the middle estimate is 1.1-fold (0.03 log units) above the measured one, and the stated range covers the measured number.
By their numbers in this assay, from the lowest: compounds 1, 3 and 2 (each within the scatter of the next).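

In this assay, the change from phenyl to 4-methylphenyl gives a 1.4-fold lower number from compound 2 to compound 3 (0.14 log units; within the scatter), so adding this one carbon cannot be told apart from making no change at all. Going by these compounds alone, this is the first measured step at this position, on an aromatic carbon para to a large group, and it shows that a methyl can sit there with no loss beyond the scatter. No separate measurement bears on this result.

A single methyl says little about other groups at this position: an amine, a carboxylic acid, a methoxy group or a longer chain such as propyl might still move the number beyond the scatter. From the compounds shown here alone, it also remains open whether the same methyl would give a similar step on a different core.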